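Halogen swap on the aryl hydrazone of a chlorovinyl core

The source may hold more compounds than are shown below. What is called first, only, known or untested is meant among the compounds shown, and "the series" means these compounds.

Measured so far:
Compound 1, `Cc1ccc(/C=N\NC(=O)C2=C(Cl)c3ccccc3CCC2)cc1`, in a functional assay on MDA-MB-231 cells (Homo sapiens) for inhibition, read by sulforhodamine B assay, with a stated time of 48 h (on this read-out higher numbers stand for weaker inhibition of growth and lower numbers for stronger inhibition of growth), gives 260 nM.
Compound 2, `Cc1cc2c(cc1C)C(Cl)=C(C(=O)N/N=C\c1ccc(Cl)cc1)CCC2`, in this assay gives 410 nM.

Among the measured compounds shown here, compound 2 and compound 1 differ in more than one place, so no single step connects them; their two values lie within the scatter of each other and show only that the two are indistinguishable on this read-out. For the measured compounds named here, compound 2 thus has no separating step to any other measured compound and stands simply as one of two equivalent numbers.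

The next compound, compound 3, `Cc1cc2c(cc1C)C(Cl)=C(C(=O)N/N=C\c1ccc(F)cc1)CCC2`, keeps the whole of compound 2 and changes one point: fluoro in place of chloro on an aromatic carbon. Going by the values given here, nothing among the measured compounds reports what a fluoro in place of a chloro does here, and compound 1 carries a methyl at that same aromatic carbon, not a halogen, so it gives no direct guide either. Among the compounds with values here, with no counted step to lean on, the expectation is a step from compound 2 to compound 3 of a 1.5-fold higher number from compound 2 to compound 3 (0.17 log units; within the scatter), which is not expected to exceed the scatter in either direction. For compound 3 the estimate in this assay is 600 nM, with a range from 250 nM to 1500 nM.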

Compound 3, concentration for 50% growth inhibition: 840 nM
Beside the measured number, compound 3's estimate is 1.4-fold (0.15 log units) below it; measured number inside the range.
By their numbers in this assay, from the lowest: compounds 1 and 2 (each within the scatter of the next); then compound 3.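

Among the compounds shown here, compound 2 and compound 3 form the first pair that differs in one place, so the aromatic carbon para to a large group can now be read on its own. In this assay the change from 4-chlorophenyl to 4-fluorophenyl gives a 2.0-fold higher number from compound 2 to compound 3 (0.31 log units; beyond the scatter) and thus shows that this position is not indifferent to the identity of its halogen, with the fluoro compound having the higher number and so the weaker inhibition of growth. This is a modest step resting on one pair on one shared core, and no measurement shown gives a reason for it.

The compounds shown leave open whether a bromo, a trifluoromethyl, a methoxy, a nitrile or an amine at this carbon would move the number further in either direction, and where the unsubstituted phenyl would fall. They also leave open whether the same fluoro-for-chloro step holds on the core of compound 1, and how a methyl at this carbon compares with a halogen, since compound 1 differs from compound 2 in more than one place.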